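The source may hold more compounds than are shown below. What is called first, only, known or untested is meant among the compounds shown, and "the series" means these compounds.

Compound 3, `O=C1CC[C@@H](C(=O)N2CCC(NS(=O)(=O)c3cc(S(=O)(=O)c4ccccc4)ccc3C(F)(F)F)CC2)N1`, gives 90 nM in an assay on isolated protein for binding affinity to secreted frizzled-related protein 1 (Homo sapiens), read by fluorescence; on this read-out lower numbers stand for stronger inhibition and higher numbers for weaker inhibition. Among the three compounds measured, compound 3 stands second highest: its nearest neighbour is compound 2, `CC(C)(C)OC(=O)N1CCC[C@@H]1C(=O)N1CCC(NS(=O)(=O)c2cc(S(=O)(=O)c3ccccc3)ccc2C(F)(F)F)CC1`, with 120 nM, and the step of a 1.3-fold lower number from compound 2 to compound 3 (0.12 log units; within the scatter) lies within the scatter. The furthest is compound 1, `O=C(Cn1ccnc1)N1CCC(NS(=O)(=O)c2cc(S(=O)(=O)c3ccccc3)ccc2C(F)(F)F)CC1`, with 30 nM, and the step of a 3.0-fold higher number from compound 1 to compound 3 (0.48 log units; beyond the scatter) is modest, as is a 4.0-fold higher number from compound 1 to compound 2 (0.60 log units; beyond the scatter). Compound 4, `CC(C)(C)CC(=O)N1CCC[C@H]1C(=O)N1CCC(NS(=O)(=O)c2cc(S(=O)(=O)c3ccccc3)ccc2C(F)(F)F)CC1`, differs from compound 3 by 1-(neopentylcarbonyl)pyrrolidin-2-yl in place of 5-oxopyrrolidin-2-yl on a carbonyl carbon. The step from compound 2 to compound 3 bears most directly on this change, since compound 2 also carries an acylated pyrrolidine, and it stayed within the scatter. Compound 4 is therefore expected to show a 1.2-fold higher number from compound 3 to compound 4 (0.09 log units; within the scatter), no move beyond the scatter. The estimate for compound 4 is 110 nM, within 45 nM to 280 nM.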

Compound 4, half-maximal inhibitory concentration: 20 nM
Compound 4: middle estimate off by 5.5-fold (0.74 log units), on the high side; measured number below the stated range.
By their numbers in this assay, from the lowest: compounds 4 and 1 (each within the scatter of the next); then compounds 3 and 2 (each within the scatter of the next).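

Acylated pyrrolidines on this carbonyl carbon do not all behave alike: 1-(neopentylcarbonyl)pyrrolidin-2-yl improves on 1-(tert-butoxycarbonyl)pyrrolidin-2-yl (a 6.0-fold lower number from compound 2 to compound 4 (0.78 log units; beyond the scatter)) and on 5-oxopyrrolidin-2-yl (a 4.5-fold lower number from compound 3 to compound 4 (0.65 log units; beyond the scatter)). It also stands level with (1H-imidazol-1-yl)methyl (a 1.5-fold lower number from compound 1 to compound 4 (0.18 log units; within the scatter)), so this position tolerates a far larger group than compound 1 alone suggested. No available evidence accounts for the gain.

From the compounds shown here alone, whether the gain rests on the neopentyl chain or on the stereocentre, drawn opposite in compound 2 and compound 4, remains open. Also open, going by these compounds, is what a shorter acyl chain or a free amine on the pyrrolidine nitrogen would give.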